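The source may report more compounds than this note shows. Statements on the series, on what has been measured and on what is new or still open speak of the compounds shown alone.

Within the data shown here, in an assay on isolated protein for inhibition of Amine oxidase [flavin-containing] A (Rattus norvegicus) (a higher number here means a weaker inhibitor, a lower number a stronger inhibitor), compound 2 `CCNCc1cn(Cc2ccccc2)c2ccccc12` gives 262000 nM, one of only two numbers measured, and the other, from compound 1 `c1ccc(CNCc2cn(Cc3ccccc3)c3ccccc23)cc1` at 244000 nM, lies within the scatter of it, with a 1.1-fold higher number from compound 1 to compound 2 (0.03 log units; within the scatter). Compound 3 `CC(C)NCc1cn(Cc2ccccc2)c2ccccc12` differs from compound 2 by methyl in place of hydrogen on a saturated chain carbon bound to an amine nitrogen and a saturated chain carbon. Among the measured compounds shown here, the single measured step, which swapped groups at this same carbon, bears on the change, and since it was within the scatter, no step beyond the scatter is expected in this assay. Compound 3 is therefore expected to give 250000 nM, within a range from 100000 nM to 600000 nM. That estimate means a 1.0-fold lower number from compound 2 to compound 3 (0.02 log units; within the scatter).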

Compound 3, inhibition constant: 133000 nM
Beside the measured number, compound 3's estimate is 1.9-fold (0.27 log units) above it; the range from low to high includes it.
By their numbers in this assay, from the lowest: compounds 3, 1 and 2 (each within the scatter of the next).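

In this assay, the change from ethylamino to isopropylamino, a methyl in place of hydrogen on this saturated chain carbon, stays within the scatter (a 2.0-fold lower number from compound 2 to compound 3 (0.29 log units; within the scatter)). Isopropyl in place of benzyl on the amine nitrogen also stays within it (a 1.8-fold lower number from compound 1 to compound 3 (0.26 log units; within the scatter)), so branching at this carbon gives no step beyond the scatter among these three compounds. No measurement shown here accounts for these numbers. The compounds shown leave open whether a tert-butyl group or a longer chain on the amine nitrogen would give a step beyond the scatter.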